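The source may hold more compounds than are shown below. What is called first, only, known or untested is meant among the compounds shown, and "the series" means these compounds.

Compound 3, with the structure `CN1CCN(c2ccc(C3=NN(C(=O)c4ccc(C(F)(F)F)cc4)C(c4ccc(N(C)C)cc4)C3)cc2)CC1`, gives the highest number of the three compounds measured in a functional assay on HCC1806 cells (Homo sapiens) for inhibition, read by sulforhodamine B assay, tested at 10 uM; on this read-out higher numbers stand for more inhibition at the one concentration tested (going by the name of the read-out) and lower numbers for less inhibition: it shows 84.1%. Compound 1, with the structure `CC(=O)N1N=C(c2ccc(N3CCN(C)CC3)cc2)CC1c1ccc(N(C)C)cc1`, gives -0.8% in this assay, and compound 2, with the structure `CN1CCN(c2ccc(C3=NN(C(=O)CCCl)C(c4ccc(N(C)C)cc4)C3)cc2)CC1`, gives 1.7%. The two steps leading to compound 3 are both large: a number 84.9 percentage points higher from compound 1 to compound 3 (beyond the scatter) and a number 82.4 percentage points higher from compound 2 to compound 3 (beyond the scatter), while a number 2.5 percentage points higher from compound 1 to compound 2 (within the scatter).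

Compound 4, with the structure `CN1CCN(c2ccc(C3=NN(C(=O)/C=C/c4ccccc4)C(c4ccc(N(C)C)cc4)C3)cc2)CC1`, differs from compound 3 in one place: 2-phenylethenyl in place of 4-(trifluoromethyl)phenyl on a carbonyl carbon. For the measured compounds named here, no measured step swaps one group carrying an aromatic ring on that carbonyl carbon for another; the two large steps seen so far only show that putting 4-(trifluoromethyl)phenyl on the carbonyl carbon in place of methyl or 2-chloroethyl raised inhibition strongly. Since compound 4 still carries an aromatic ring on that carbonyl, inhibition is expected to stay well above compounds 1 and 2, with a number 19.1 percentage points lower from compound 3 to compound 4 (beyond the scatter) expected as a moderate drop that may or may not exceed the scatter. Compound 4 is therefore estimated at 65%, within a range from 25% to 92%.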

Compound 4, a percentage reported as inhibition, at one concentration (the size of the read-out at that concentration, not a potency): 71%
The estimate for compound 4 lay 6 percentage points below the measured number; the range from low to high includes it.
By their numbers in this assay, from the lowest: compounds 1 and 2 (each within the scatter of the next); then compound 4; then compound 3.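

In this assay, 2-phenylethenyl on the carbonyl carbon also gives a large gain, with a number 71.8 percentage points higher from compound 1 to compound 4 (beyond the scatter) and a number 69.3 percentage points higher from compound 2 to compound 4 (beyond the scatter) as the steps from the methyl and 2-chloroethyl groups, so high inhibition at this position does not depend on 4-(trifluoromethyl)phenyl or its fluorine atoms. Exchanging these two ring-bearing groups matters much less, although a number 13.1 percentage points lower from compound 3 to compound 4 (beyond the scatter) shows that the choice between them still has a measurable effect. No measurement here explains the difference between the two groups.

On these data alone, it remains open whether the aromatic ring, the double bond or simply a larger group accounts for the gain. A plain phenyl, a saturated 2-phenylethyl or a long alkyl chain without a ring on the same carbonyl carbon would help separate these possibilities.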